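Putting an Aromatic Ring Back on the Side Chain

The source may report more compounds than this note shows. Statements on the series, on what has been measured and on what is new or still open speak of the compounds shown alone.

Two measured compounds share one core and differ only in the group hanging from the piperidine oxygen. Compound 1 `COc1cc2nc(N3CCC(OCCOc4ccccc4)CC3)nc(N)c2cc1OC` gives 0.48 nM in an assay on brain for displacement of a labelled ligand from Adrenergic receptor alpha-1 (Rattus norvegicus); a lower number here means a stronger inhibitor, a higher number a weaker inhibitor. Compound 2 `COc1cc2nc(N3CCC(OCC(C)O)CC3)nc(N)c2cc1OC` gives 3.52 nM in this assay, the higher of the two numbers, so compound 2 is the weaker inhibitor of the pair. The gap between them, a 7.3-fold higher number from compound 1 to compound 2 (0.87 log units; beyond the scatter), came with 1-hydroxyethyl in place of phenoxymethyl on a saturated chain carbon bound to an oxygen on a saturated carbon.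

Compound 3 `CCOC(COC1CCN(c2nc(N)c3cc(OC)c(OC)cc3n2)CC1)c1ccccc1` has not yet been measured. It differs from compound 2 by ethoxy(phenyl)methyl in place of 1-hydroxyethyl on a saturated chain carbon bound to an oxygen on a saturated carbon. Going by the values given here, the only measured step that bears on this change is a 7.3-fold higher number from compound 1 to compound 2 (0.87 log units; beyond the scatter), where a chain carrying a six-membered aromatic ring was replaced by 1-hydroxyethyl and the number rose. Compound 3 moves the other way, putting an aromatic ring back on the chain, though in a different arrangement than compound 1 had. The expected step is therefore a 3.9-fold lower number from compound 2 to compound 3 (0.59 log units; beyond the scatter), a fall in the number. The estimate for compound 3 in this assay is 0.9 nM, with a range from 0.3 nM to 3 nM.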

Compound 3, inhibition constant: 0.52 nM
Beside the measured number, compound 3's estimate is 1.7-fold (0.24 log units) above it; low and high end bracket the measured number.
By their numbers in this assay, from the lowest: compounds 1 and 3 (each within the scatter of the next); then compound 2.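

In this assay, replacing 1-hydroxyethyl with ethoxy(phenyl)methyl gives a 6.8-fold lower number from compound 2 to compound 3 (0.83 log units; beyond the scatter) and so recovers about as much as the step away from phenoxymethyl had lost. The two ring-bearing groups hold the ring in different arrangements, yet the change between them gives a 1.1-fold higher number from compound 1 to compound 3 (0.03 log units; within the scatter) and leaves no readable difference, so at this position the assay does not separate these two arrangements, and among the three compounds both chains with a six-membered aromatic ring sit clear of the ringless chain of compound 2. No measurement shown here explains why these numbers fall as they do.

Compound 3 gains the ring and loses the hydroxyl in a single change, so the compounds shown cannot say which of the two matters, or whether both do. A 2-hydroxy-2-phenylethyl chain, which carries both the ring and the hydroxyl, would pull these apart, while a chain ending in an amine or a carboxylic acid would test whether anything other than an aromatic ring can give numbers this low.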